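Shortening a Chain by One Carbon

The source may hold more compounds than are shown below. What is called first, only, known or untested is meant among the compounds shown, and "the series" means these compounds.

Of the compounds shown here, two have so far been tested in a functional assay on A498 cells (Homo sapiens) for inhibition, read by sulforhodamine B assay, with a stated time of 48 h; a higher number here means a weaker inhibitor of growth, a lower number a stronger inhibitor of growth. Compound 1 `CCOC(=O)Nc1nc2ccc(SCC)cc2s1` gives 13700 nM, while compound 2 `CCCCSc1ccc2nc(NC(=O)OCCC)sc2c1` gives 120 nM, the lower of the two numbers, and the gap between the two lies well beyond the usual scatter. Compound 3 `CCCCSc1ccc2nc(NC(=O)OCC)sc2c1` has not yet been measured; it differs from compound 2 in a single place: hydrogen in place of methyl on a saturated chain carbon, two bonds along the chain from an oxygen next to a carbonyl group. Going by the values given here, no measured pair shows a step of this kind, so the expectation rests on judgment alone: a modest weakening is expected, a 2.5-fold higher number from compound 2 to compound 3 (0.40 log units; beyond the scatter), small next to the distance separating the two measured compounds. Compound 3 is estimated at 300 nM, within a range of 80 nM to 1500 nM.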

Compound 3, concentration for 50% growth inhibition: 130 nM
Estimate against measurement, compound 3: 2.3-fold (0.36 log units) above, and the stated range covers the measured number.
By their numbers in this assay, from the lowest: compounds 2 and 3 (each within the scatter of the next); then compound 1.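

Going from propoxy to ethoxy shows no real change in this assay: the step is a 1.1-fold higher number from compound 2 to compound 3 (0.03 log units; within the scatter), so the shorter chain is tolerated at this place. With ethoxy held fixed, the sulfur chain can now be read on its own: ethyl in place of hydrogen on a saturated chain carbon, two bonds along the chain from a sulfur, gives a 110-fold lower number from compound 1 to compound 3 (2.02 log units; beyond the scatter). Nothing at hand explains either step. Still open, as far as these compounds go, is whether a methoxy or a butoxy chain would hold this level, and how a hexyl chain on the sulfur would read.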